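Swapping 2-hydroxyethyl for 1-(hydroxymethyl)ethenyl

The compounds below may be only part of what the source reports. "The series", "measured", "known", "first", "only" and "open" are said of these compounds alone.

Compound 1 `C=C(CO)C(CCCCC)n1cnc2c(Cl)ncnc21`: > 50000 nM (a limit)
Compound 2 `CCCCCCCC(CCO)n1cnc2c(Cl)ncnc21`: 4160 nM

Among the measured compounds shown here, in a functional assay on HCT-116 cells (Homo sapiens) for antiproliferative activity, read by MTT assay, with a stated time of 48 h (on this read-out lower numbers stand for stronger inhibition and higher numbers for weaker inhibition), compound 2 gives 4160 nM, the only exact number so far. Compound 3 `C=C(CO)C(CCCCCCC)n1cnc2c(Cl)ncnc21` carries 1-(hydroxymethyl)ethenyl in place of 2-hydroxyethyl on a saturated chain carbon bound to an aromatic nitrogen and a saturated chain carbon. Compound 1, which also carries 1-(hydroxymethyl)ethenyl, reports only the limit > 50000 nM. For the measured compounds named here, with that limit as the sole guide, a moderate weakening in this assay is expected, an estimated 1.9-fold higher number from compound 2 to compound 3 (0.28 log units; within the scatter). For compound 3 the expected value is 8000 nM, with an estimated range of 2000 nM to 30000 nM.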

Compound 3, half-maximal inhibitory concentration: 22400 nM
The estimate for compound 3 lay 2.8-fold (0.45 log units) below the measured number, and the stated range covers the measured number.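

Compound 3 gives an exact number for 1-(hydroxymethyl)ethenyl on this saturated chain carbon, and swapping in that group for 2-hydroxyethyl weakens activity, with a 5.4-fold higher number from compound 2 to compound 3 (0.73 log units; beyond the scatter). Ethyl in place of hydrogen on a saturated chain carbon, which separates the two compounds carrying 1-(hydroxymethyl)ethenyl, acts in the opposite direction, with an at least 2.2-fold lower number from compound 1 to compound 3 (0.34 log units; beyond the scatter). The value of compound 1 is a limit, so this step gives only a bound on the size of the change: the limit of > 50000 nM in this assay, at which 1 of the 3 values shown sits.

The compounds shown leave open whether a longer chain would lower the number further. They also leave open how an amine in place of the hydroxyl of 1-(hydroxymethyl)ethenyl would compare.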